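Swapping one halogen for another on a chalcone hydrazone

The source may hold more compounds than are shown below. What is called first, only, known or untested is meant among the compounds shown, and "the series" means these compounds.

Of the compounds shown here, two have been tested so far. Compound 1 `O=C(/C=C/c1ccc(/C=N/NC(=O)c2ccncc2)cc1)c1cccc(Br)c1` carries a 3-bromophenyl on its carbonyl carbon, and compound 2 `O=C(N/N=C/c1ccc(/C=C/C(=O)c2ccccc2F)cc1)c1ccncc1` carries a 2-fluorophenyl there instead. In a functional assay on the whole organism (Ear) for inhibition, with Mus musculus as the target, with a stated time of 30 min, at a dose of 100 mg/kg by the intraperitoneal route (on this read-out lower numbers stand for less inhibition and higher numbers for more inhibition at the one dose given (going by the name of the read-out)), compound 1 gives 14%, and in this assay compound 2 gives 51.3%. Among the compounds with values here, this makes compound 2 the higher of the two numbers, the only measured step being a number 37.3 percentage points higher from compound 1 to compound 2 (beyond the scatter).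

Compound 3 `O=C(N/N=C/c1ccc(/C=C/C(=O)c2ccccc2Br)cc1)c1ccncc1` has not yet been measured. It differs from compound 2 in one place: bromo in place of fluoro on an aromatic carbon. Within the data shown here, the only measured step bears on this change indirectly, since going from compound 1 to compound 2 exchanged bromine for fluorine but also moved the halogen to a different position on the ring, so the two effects cannot be separated. Returning to bromine while keeping the position of compound 2 could therefore give back part of that step, or none of it.

The expectation for compound 3 is a modest drop, a number 11.3 percentage points lower from compound 2 to compound 3 (beyond the scatter), with wide uncertainty. Compound 3 is estimated to give 40% in this assay, within a range from 15% to 65%.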

Compound 3, a percentage reported as inhibition, in the whole organism at one dose (the size of the read-out at that dose, not a potency): 48.7%
For compound 3 the middle estimate is 8.7 percentage points below the measured one; the range from low to high includes it.
By their numbers in this assay, from the lowest: compound 1; then compounds 3 and 2 (each within the scatter of the next).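

In this assay, the change from 2-fluorophenyl to 2-bromophenyl gives a number 2.6 percentage points lower from compound 2 to compound 3 (within the scatter) and so leaves the two compounds indistinguishable, which means that at this aromatic carbon, ortho to a large group, the read-out does not separate fluoro from bromo. With bromine kept on both compounds, moving from 3-bromophenyl to 2-bromophenyl gives a number 34.7 percentage points higher from compound 1 to compound 3 (beyond the scatter) and resolves what the earlier step had mixed: across these three compounds, the large difference goes with where the halogen sits on the ring, not with which of the two halogens is present. Nothing at hand explains either step.

The compounds shown do not tell whether a halogen is needed at this position at all, since an unsubstituted phenyl, a methoxy group, an amine or a carboxylic acid on the same carbon could give quite different numbers. Each compound also has a number at only one dose, so these results describe the size of the effect at that dose and leave open how potency compares across the series.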